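Smaller group on the carbonyl carbon: compound 4 expected

The source may report more compounds than this note shows. Statements on the series, on what has been measured and on what is new or still open speak of the compounds shown alone.

Measured compounds:
- compound 1, `CCC(=O)Nc1c(C(O)(C(F)(F)F)C(F)(F)F)ccc2ccccc12`, 15 nM
- compound 2, `CCC(CC)C(=O)Nc1c(C(O)(C(F)(F)F)C(F)(F)F)ccc2ccccc12`, 4340 nM
- compound 3, `CCCC(C)C(=O)Nc1c(C(O)(C(F)(F)F)C(F)(F)F)ccc2ccccc12`; for compound 3 only a limit is known, > 10000 nM

All three share one core and differ only in the group on the carbonyl carbon. In an assay on LtK cells with ATP-sensitive inward rectifier potassium channel 11 (Homo sapiens) as the target (on this read-out higher numbers stand for an effect only at larger amounts of compound and lower numbers for an effect already at smaller amounts), compound 1 gives 15 nM, while compound 2 gives 4340 nM, the highest number among the two compounds with a full value. The step of a 290-fold higher number from compound 1 to compound 2 (2.46 log units; beyond the scatter) shows that replacing ethyl by pentan-3-yl costs a great deal. Compound 3 reaches only the limit (the limit of > 10000 nM in this assay, at which 1 of the 3 values shown sits), and the step of an at least 660-fold higher number from compound 1 to compound 3 (2.82 log units; beyond the scatter) is of similar size. Within the two branched groups, an at least 2.3-fold higher number from compound 2 to compound 3 (0.36 log units; beyond the scatter) adds a further smaller loss.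

Compound 4, `O=C(Nc1c(C(O)(C(F)(F)F)C(F)(F)F)ccc2ccccc12)C1CC1`, is not yet measured. Its change from compound 2 is cyclopropyl in place of pentan-3-yl on a carbonyl carbon: the entering group is smaller than the leaving one and is a ring. Since the only large steps shown run from the small ethyl group to the larger branched groups, compound 4 is expected to move back toward compound 1, though how far is uncertain. The step of a 29-fold lower number from compound 2 to compound 4 (1.46 log units; beyond the scatter) is therefore expected to be a clear decrease. Compound 4 is expected to give about 150 nM, between 20 nM and 1500 nM.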

Compound 4, half-maximal effective concentration: 751 nM
For compound 4 the middle estimate is 5.0-fold (0.70 log units) below the measured one, within the range that was stated.
By their numbers in this assay, from the lowest: compound 1; then compound 4; then compound 2. At a limit, above all of these: compound 3.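

Cutting the group on the carbonyl carbon down to cyclopropyl wins back only part of what pentan-3-yl cost, with a 5.8-fold lower number from compound 2 to compound 4 (0.76 log units; beyond the scatter), and even this small ring falls well short of ethyl, with a 50-fold higher number from compound 1 to compound 4 (1.70 log units; beyond the scatter), so this position responds strongly to a change between two small groups. Against 1-methylbutyl, the cyclopropyl group gives an at least 13-fold lower number from compound 3 to compound 4 (1.12 log units; beyond the scatter). The size of that last step is only a bound, set by a limit: the limit of > 10000 nM in this assay, at which 1 of the 4 values shown sits.

The compounds shown leave open whether the ring itself or some other difference from ethyl accounts for the gap in this assay. A methyl group, an unbranched propyl chain or a cyclobutyl ring on the same carbonyl carbon would help to separate these possibilities.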